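The source may report more compounds than this note shows. Statements on the series, on what has been measured and on what is new or still open speak of the compounds shown alone.

Measured so far:
compound 1 `O=c1oc2cccnc2n1CCN1CCN(c2ccccc2)CC1` gives 19.4 mg/kg
compound 2 `COc1ccccc1N1CCN(CCn2c(=O)oc3cccnc32)CC1` reaches only the assay limit > 50 mg/kg
compound 3 `O=c1oc2cccnc2n1CCN1CCN(c2ccc(F)cc2)CC1` gives 41.3 mg/kg

In a functional assay on the whole organism with Mus musculus as the target (a higher number here means that more compound is needed for the effect, a lower number that less compound is needed), compound 3 stands highest of the two numbers shown, its nearest neighbour being compound 1 with a 2.1-fold higher number from compound 1 to compound 3 (0.33 log units; beyond the scatter). Compound 4 `O=c1oc2cccnc2n1CCN1CCN(c2ccc(Oc3ccccc3)cc2)CC1` differs from compound 3 in one place: phenoxy in place of fluoro on an aromatic carbon. Going by the values given here, two measured steps bear on this change, both substitutions on the same aromatic carbon ring of the shared core: a 2.1-fold higher number from compound 1 to compound 3 (0.33 log units; beyond the scatter) and an at least 2.5-fold higher number from compound 1 to compound 2 (0.41 log units; beyond the scatter), and note (the limit of > 50 mg/kg in this assay, at which 1 of the 3 values shown sits). Each group entering that ring raised the number, so a larger group entering is expected to raise it further, a 1.6-fold higher number from compound 3 to compound 4 (0.20 log units; within the scatter), with a real chance that only a limit is reported. Compound 4 is expected at 65 mg/kg, range 25 mg/kg to 160 mg/kg.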

Compound 4, dose for half-maximal effect: > 50 mg/kg
Compound 4: no number, only a limit; the forecaster's own chance of this, stated with the estimate: 55%; the middle value lies beyond the limit too.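

In this assay compound 4 gives > 50 mg/kg, which is a limit and not a number. Phenoxy in place of hydrogen gives an at least 2.5-fold higher number from compound 1 to compound 4 (0.41 log units; beyond the scatter), so a group with its own aromatic ring at this place also leaves the number higher than in compound 1, as methoxy and fluoro did. Phenoxy in place of fluoro gives an at least 1.2-fold higher number from compound 3 to compound 4 (0.08 log units; that floor lies within the scatter), a floor only, so the true size of this change stays unread: the limit of > 50 mg/kg in this assay, at which 2 of the 4 values shown sit.

Open, as far as these compounds go, is whether any group on this aromatic ring lowers the number relative to compound 1, for example an amine or a carboxylic acid. Also open, from the compounds shown here alone, is whether a longer chain between the shared core and the piperazine-bearing part changes this picture.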